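The source may report more compounds than this note shows. Statements on the series, on what has been measured and on what is new or still open speak of the compounds shown alone.

Measured so far:
- compound 1, `COc1ccc(OC)c(S(=O)(=O)NC(=O)c2ccc(Cn3ccc4ccc(NC(=O)CC5CCCC5)cc43)c(OC)c2)c1`, in a functional assay (trachea) for antagonist activity, with Cavia porcellus as the target (on this read-out lower numbers stand for lower potency and higher numbers for higher potency (the scale is a negative logarithm)), compound 1 gives 9.1
- compound 2, `COC(=O)C(C(=O)c1ccc(Cn2ccc3ccc(NC(=O)CC4CCCC4)cc32)c(OC)c1)S(=O)(=O)c1ccccc1`, in this assay compound 2 gives 10.1

Of the two numbers, compound 1 is the lower one, and the gap to compound 2 is larger than the usual scatter; the two structures differ in several places, so nothing more is drawn from that pair.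

Compound 3, `COc1cc(C(=O)NS(=O)(=O)c2ccccc2OC)ccc1Cn1ccc2ccc(NC(=O)CC3CCCC3)cc21`, is the unmeasured one. It arises from compound 1 by hydrogen in place of methoxy on an aromatic carbon. For the measured compounds named here, no step between measured compounds of this kind is available, so the account leans on the modest size of the change. The step from compound 1 to compound 3 in this assay is expected to be small, a slight decrease or none beyond the scatter, a number 0.10 log units lower from compound 1 to compound 3 (within the scatter). Compound 3 is therefore estimated at 9, within 8.4 to 9.6.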

Compound 3, negative logarithm of the antagonist equilibrium constant: 9.7
Beside the measured number, compound 3's estimate is 0.70 log units below it, outside the stated range (above it).
By their numbers in this assay, from the lowest: compound 1; then compound 3; then compound 2.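

Hydrogen in place of methoxy on an aromatic carbon, which turns 2,5-dimethoxyphenyl into 2-methoxyphenyl, gives a number 0.60 log units higher from compound 1 to compound 3 (beyond the scatter) in this assay. For the compounds shown here, this is the first comparison here that isolates a single place, as compounds 1 and 2 differ in several, and it shows that the methoxy group meta to a large group and para to a methoxy group is not required for this level of potency; its removal raises the number. Nothing at hand accounts for the gain.

As far as these compounds go, whether the gain comes simply from losing the methoxy group remains open, as a fluorine atom, a methyl group or an amine at this place would be needed to tell. Going by these compounds alone, the part played by the remaining methoxy group is also unresolved, since no phenyl compound without it appears here.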